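Trifluoromethyl on the open-chain dithiol amide

The source may hold more compounds than are shown below. What is called first, only, known or untested is meant among the compounds shown, and "the series" means these compounds.

Measured in a functional assay on HO8910 cells (Homo sapiens) for inhibition, read by MTT assay, with a stated time of 24 h, tested at 100 ug/mL; on this read-out lower numbers stand for less inhibition of growth and higher numbers for more inhibition of growth at the one concentration tested:
compound 1 `O=C(CCCCC1CCSS1)Nc1cccc(C(F)(F)F)c1`: 74.8%
compound 2 `O=C(CCCCC(S)CCS)Nc1ccccc1`: 13.7%
compound 3 `O=C(CCCCC(S)CCS)Nc1ccc(Cl)cc1`: 21.3%

Compound 2, at 13.7%, lies within the scatter of compound 3 and far under compound 1. Compound 4 `O=C(CCCCC(S)CCS)Nc1cccc(C(F)(F)F)c1` carries trifluoromethyl in place of hydrogen on an aromatic carbon. For the measured compounds named here, the one measured step on that ring is a number 7.6 percentage points higher from compound 2 to compound 3 (within the scatter), a chloro exchange that stays within the scatter. Going by the values given here, compound 1 also bears trifluoromethyl but differs elsewhere, and no measured step separates those two changes, so its value gives only weak support for a larger rise. A modest upward step in this assay is therefore expected, probably not beyond the scatter. The expected change is a number 8.3 percentage points higher from compound 2 to compound 4 (within the scatter). For compound 4 the estimated value is 22%, with an expected range from 10% to 42%.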

Compound 4, percent growth inhibition at one concentration: 34.8%
Compound 4: the middle estimate sits 12.8 percentage points below what was measured; low and high end bracket the measured number.
By their numbers in this assay, from the lowest: compounds 2 and 3 (each within the scatter of the next); then compound 4; then compound 1.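

In this assay, trifluoromethyl on an aromatic carbon, meta to a large group, gives a number 21.1 percentage points higher from compound 2 to compound 4 (beyond the scatter) and so moves the open-chain dithiol amide beyond the scatter, which the chloro exchange with a number 7.6 percentage points higher from compound 2 to compound 3 (within the scatter) did not do. With trifluoromethyl held constant, the open-chain group in place of the five-membered ring gives a number 40 percentage points lower from compound 1 to compound 4 (beyond the scatter) as the larger of the two new steps. Nothing available explains either step. The compounds shown leave open whether a nitrile or a methoxy group at this place would give a similar rise, and how the ring form of the core responds to trifluoromethyl in place of hydrogen.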